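Returning to a Ring Amine on the Side Chain

The source may hold more compounds than are shown below. What is called first, only, known or untested is meant among the compounds shown, and "the series" means these compounds.

Measured so far in an assay for inhibition of Caspase-8 (Homo sapiens); on this read-out lower numbers stand for stronger inhibition and higher numbers for weaker inhibition:
compound 1, `CCC(C(=O)N[C@@H](CC(=O)O)C(=O)CNCN1CCc2ccccc2C1)n1ccnc(NCc2nonc2C)c1=O`: 7380 nM
compound 2, `CCCCCCN(C)CNCC(=O)[C@H](CC(=O)O)NC(=O)C(CC)n1ccnc(NCc2nonc2C)c1=O`: > 10000 nM

Compound 1 gives 7380 nM in this assay. Compound 2 returns only > 10000 nM, which is a limit of the assay and not a number. This is the limit of > 10000 nM in this assay, at which 1 of the 2 values shown sits. Among the measured compounds shown here, the single measured step, an at least 1.3-fold higher number from compound 1 to compound 2 (0.13 log units; that floor lies within the scatter), therefore has only a floor, and that floor lies within the scatter, so nothing more than a small or no change can be read from it.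

Compound 3, `CCC(C(=O)N[C@@H](CC(=O)O)C(=O)CNCN1CCCC1)n1ccnc(NCc2nonc2C)c1=O`, is not yet measured. Against compound 2 the change is pyrrolidin-1-yl in place of hexyl(methyl)amino on a saturated chain carbon bound to an amine nitrogen. The step from compound 1 to compound 2 bears on this change, since it exchanged a ring amine for an open-chain amine; compound 3 brings a ring amine back, though a smaller one. The expectation is a modest return toward the number of compound 1, so for compound 3 the expected step is an at least 1.1-fold lower number from compound 2 to compound 3 (0.04 log units; that floor lies within the scatter), with a real chance that the assay again reports only a limit. The estimate for compound 3 is 9000 nM, expected to fall between 3500 nM and 25000 nM.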

Compound 3, half-maximal inhibitory concentration: 6220 nM
For compound 3 the middle estimate is 1.4-fold (0.16 log units) above the measured one; the measured number falls inside the stated range.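

In this assay, the exchange of 1,2,3,4-tetrahydroisoquinolin-2-yl for pyrrolidin-1-yl on a saturated chain carbon bound to an amine nitrogen gives a 1.2-fold lower number from compound 1 to compound 3 (0.07 log units; within the scatter), so these two ring amines cannot be told apart at this place, although they differ clearly in size. Against the open-chain hexyl(methyl)amino, the step is an at least 1.6-fold lower number from compound 2 to compound 3 (0.20 log units; that floor lies within the scatter), so even this floor does not establish that a ring amine gives a lower number than an open-chain amine here. Compound 2 still provides only a limit of the assay, not a number: the limit of > 10000 nM in this assay, at which 1 of the 3 values shown sits.

The compounds shown leave open whether a six-membered ring such as piperidin-1-yl, or a ring with an oxygen atom such as morpholin-4-yl, would read any differently at this place. A short open-chain amine such as dimethylamino would help to show whether the limit seen for compound 2 goes with the open-chain amine in general or with its hexyl chain in particular.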